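Methyl to methoxy on the pendant aryl ring: series notes

The source may report more compounds than this note shows. Statements on the series, on what has been measured and on what is new or still open speak of the compounds shown alone.

Measured compounds in a functional assay on HT-29 cells (Homo sapiens) for cytotoxicity, read by MTT assay, with a stated time of 72 h; on this read-out lower numbers stand for stronger inhibition and higher numbers for weaker inhibition:
- compound 1 `COc1ccc(-c2cc(C(=O)Nc3ccc(Oc4ccnc5cc(OCCCN6CCC(C)CC6)c(OC)cc45)c(F)c3)c3ccccc3n2)cc1` gives 1110 nM
- compound 2 `COc1cc2c(Oc3ccc(NC(=O)c4cc(-c5ccc(C)cc5)nc5ccccc45)cc3F)ccnc2cc1OCCCN1CCC(C)CC1` gives 3150 nM
- compound 3 `COc1cc2c(Oc3ccc(NC(=O)c4cc(-c5ccc(C)cc5)nc5ccc(F)cc45)cc3F)ccnc2cc1OCCCN1CCCCC1` gives 500 nM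

Compound 3 stands lowest of the three; its nearest neighbour is compound 1, and compound 2 lies furthest, both gaps beyond the usual scatter. Going by the values given here, the one single-point change measured so far is the step of a 2.8-fold lower number from compound 2 to compound 1 (0.45 log units; beyond the scatter), a modest move, described as methoxy in place of methyl on an aromatic carbon.

Compound 4 `COc1ccc(-c2cc(C(=O)Nc3ccc(Oc4ccnc5cc(OCCCN6CCCCC6)c(OC)cc45)c(F)c3)c3cc(F)ccc3n2)cc1` is not yet measured. It relates to compound 3 by methoxy in place of methyl on an aromatic carbon, the same change as that from compound 2 to compound 1, placed identically. The difference between the core of compound 3 and the core of compound 2 is not broken down here, so whether the earlier step carries over to this core rests on a single observation.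

Among the compounds with values here, for compound 4 a step of a 2.2-fold lower number from compound 3 to compound 4 (0.34 log units; beyond the scatter) is expected, somewhat tempered relative to the earlier one because only one precedent a 2.8-fold lower number from compound 2 to compound 1 (0.45 log units; beyond the scatter) supports it. Compound 4 is therefore estimated at 230 nM, with a range from 100 nM to 600 nM.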

Compound 4, half-maximal inhibitory concentration: 600 nM
Beside the measured number, compound 4's estimate is 2.6-fold (0.42 log units) below it, and the stated range covers the measured number.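

In this assay, the change from 4-methylphenyl to 4-methoxyphenyl gives a 1.2-fold higher number from compound 3 to compound 4 (0.08 log units; within the scatter), so on this core the swap has no effect that can be told from the scatter. The change therefore does not carry over in size from one core to the other: the same change on two cores in this assay, a 2.8-fold lower number (0.45 log units; beyond the scatter) from compound 2 to compound 1 and a 1.2-fold higher number (0.08 log units; within the scatter) from compound 3 to compound 4, 3.4-fold (0.53 log units) apart, beyond the scatter of two such steps. Going by these compounds alone, this rests on only two pairs and does not give a rule for the series; since the two cores differ in more than one place, these pairs also cannot show which difference goes with the loss of the earlier step.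

Open, from the compounds shown here alone, is which of the differences between the two cores decides whether the step appears, a question for pairs of cores that differ in one place only. Also open, going by these compounds, is how other groups at this same place on the pendant ring, such as ethoxy, chlorine or a dimethylamino group, would behave on either core.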